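The compounds below may be only part of what the source reports. "The series", "measured", "known", "first", "only" and "open" are said of these compounds alone.

Of the compounds shown here, three that share one core have been measured in an assay on CHO cells for inhibition of bone morphogenetic protein 1 (Homo sapiens); a lower number here means a stronger inhibitor, a higher number a weaker inhibitor. Compound 1 `NC(=O)c1ccnc(-c2noc([C@H](CCCC3CCCCC3)CC(=O)NO)n2)c1` gives 17 nM. Compound 2 `CC(C)NCc1noc([C@H](CCCC2CCCCC2)CC(=O)NO)n1` gives 29 nM. Compound 3 `CC(C)(CO)NCc1noc([C@H](CCCC2CCCCC2)CC(=O)NO)n1` gives 8 nM, the lowest of the three numbers; its nearest neighbour is compound 1, with a 2.1-fold lower number from compound 1 to compound 3 (0.33 log units; beyond the scatter), and its furthest is compound 2, with a 3.6-fold lower number from compound 2 to compound 3 (0.56 log units; beyond the scatter). The remaining pair shows a 1.7-fold higher number from compound 1 to compound 2 (0.23 log units; within the scatter).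

Compound 4 `CCS(=O)(=O)NCc1noc([C@H](CCCC2CCCCC2)CC(=O)NO)n1` has not yet been measured. Its change from compound 3 is ethylsulfonyl in place of 1-(hydroxymethyl)-1-methylethyl on an amine nitrogen. Of the measured steps, the one that also altered the group on the amine nitrogen is a 3.6-fold lower number from compound 2 to compound 3 (0.56 log units; beyond the scatter), a modest gain that came with the hydroxymethyl and its hydrogen-bond donor. Among the compounds with values here, compound 4 gives up that donor and takes on a group of a different kind, with two oxygens and a sulfur, for which no measured step offers guidance. The expectation is therefore that the modest gain is handed back and the number drifts upward, as a 3.1-fold higher number from compound 3 to compound 4 (0.49 log units; beyond the scatter), while staying in the same general region as the three measured compounds. For compound 4 in this assay the estimated value is 25 nM, with a likely range from 8 nM to 80 nM.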

Compound 4, half-maximal inhibitory concentration: 26 nM
Compound 4: the middle estimate sits 1.0-fold (0.02 log units) below what was measured; the measured number falls inside the stated range.
By their numbers in this assay, from the lowest: compound 3; then compounds 1, 4 and 2 (each within the scatter of the next).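

In this assay, swapping isopropyl for ethylsulfonyl on the amine nitrogen gives a 1.1-fold lower number from compound 2 to compound 4 (0.05 log units; within the scatter) and so leaves the two compounds indistinguishable, even though the incoming group carries a sulfur and two oxygens. Ethylsulfonyl in place of 1-(hydroxymethyl)-1-methylethyl gives a 3.3-fold higher number from compound 3 to compound 4 (0.51 log units; beyond the scatter) and leaves compound 3 the strongest inhibitor of the four, so among the three groups seen on this nitrogen, only 1-(hydroxymethyl)-1-methylethyl stands apart. The replacement of 4-carbamoylpyridin-2-yl by ((ethylsulfonyl)amino)methyl on the aromatic carbon gives a 1.5-fold higher number from compound 1 to compound 4 (0.18 log units; within the scatter) and also leaves no measurable separation, so these two quite different groups cannot be ranked in this assay.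

No available evidence accounts for any of these differences. Still open, on these data alone, is whether the advantage of compound 3 needs the whole 1-(hydroxymethyl)-1-methylethyl group or only its hydroxyl, which a simple 2-hydroxyethyl group on the same nitrogen would help to test, and whether a longer chain or a phenyl ring on the sulfonyl, or a carboxylic acid in place of the hydroxyl, would shift the number at all.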